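This account rests on a few compounds, and the source may have more. Where it says the series, first, only, none or still open, it means among the compounds named here.

In a functional assay on MV4-11 cells (Homo sapiens) for antiproliferative activity, with a stated time of 6 days, tested at 1.56 uM (a lower number here means a weaker effect, a higher number a stronger effect of the compound at the concentration tested), three compounds that share one core have been examined. Compound 1 `CNC(=O)N1CCCc2ccc(NC(=O)c3cccc(-c4ccccc4)c3)cc21` gives 2.83%, and compound 3 `CNC(=O)N1CCCc2ccc(NC(=O)c3ccccc3-c3ccccc3)cc21` gives 10.7%. Compound 2 `CNC(=O)N1CCCc2ccc(NC(=O)c3ccc(-c4ccn(C)n4)cc3)cc21` gives 72.2%, the highest of the three numbers; the nearest is compound 3, whose number lies lower by more than the usual scatter, and the furthest is compound 1, lower still and again beyond the scatter. Compound 4 `CNC(=O)N1CCCc2ccc(NC(=O)c3ccc(-c4cnn(S(C)(=O)=O)c4)cc3)cc21` has not yet been measured. It differs from compound 2 in one place: 1-(methylsulfonyl)-1H-pyrazol-4-yl in place of 1-methyl-1H-pyrazol-3-yl on an aromatic carbon. No step between measured compounds that differ in a single place is available, so this change has no direct precedent among the numbers shown. The expected step of a number 17.2 percentage points lower from compound 2 to compound 4 (beyond the scatter) is downward and of modest size, possibly not beyond the scatter. Compound 4 is therefore estimated at 55%, within a range from 20% to 85%.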

Compound 4, a percentage reported as inhibition, at one concentration (the size of the read-out at that concentration, not a potency): 4.5%
Compound 4: middle estimate off by 50.5 percentage points, on the high side, outside the stated range (below it).
By their numbers in this assay, from the lowest: compounds 1, 4 and 3 (each within the scatter of the next); then compound 2.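

In this assay, the only single-place change among these compounds gives a large step, a number 67.7 percentage points lower from compound 2 to compound 4 (beyond the scatter), when 1-(methylsulfonyl)-1H-pyrazol-4-yl replaces 1-methyl-1H-pyrazol-3-yl on the aromatic carbon para to a large group. Two groups that each hold one five-membered aromatic ring with 2 hetero atoms are therefore not interchangeable at this position. Nothing available accounts for the loss. The change moves the ring's point of attachment and also swaps methyl for methylsulfonyl, and the compounds shown do not separate these two differences. Also open, going by these compounds, is how 1-methyl-1H-pyrazol-4-yl or a morpholine would behave at this position.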